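This account rests on a few compounds, and the source may have more. Where it says the series, first, only, none or still open, it means among the compounds named here.

Measured so far:
Compound 1, `CC[C@@H](Nc1c(C#N)c(-c2ccc(-c3ccccc3CO)cc2)nc2cnccc12)C(N)=O`, gives 2.1 in a physicochemical assay for lipophilicity, read by HPLC, at pH 7.5; on this read-out lower numbers stand for lower lipophilicity and higher numbers for higher lipophilicity.
Compound 2, `CCOc1ccccc1-c1ccc(-c2nc3cnccc3c(N[C@@H]3CCOC3=O)c2C#N)cc1`, gives 2.7 in this assay.
Compound 3, `CC[C@@H](Nc1c(C#N)c(-c2ccc(-c3cccc(C)c3F)cc2)nc2cnccc12)C(=O)O`, gives 2.1 in this assay.

Among these three numbers, compound 1 stands level with compound 3 at the digits shown, and the two together are the lowest of the set. Compound 2 is the furthest from compound 1, lying higher by a margin beyond the usual scatter of repeated measurements, so that gap can be taken as real.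

Compound 4, `CC[C@@H](Nc1c(C#N)c(-c2ccc(-c3cccc(Cl)c3OC)cc2)nc2cnccc12)C(N)=O`, has not yet been measured in this assay. It differs from compound 1 in one place:
3-chloro-2-methoxyphenyl in place of 2-(hydroxymethyl)phenyl on an aromatic carbon
The group that leaves carries one hydrogen-bond donor; the group that enters carries none and brings a chlorine in its place.

Among the compounds with values here, no step between two measured compounds that differ in exactly this way is available, so the expectation rests on the change itself. In this assay a move upward, beyond the scatter, is expected, of the size a number 1.20 log units higher from compound 1 to compound 4 (beyond the scatter). On that basis compound 4 is estimated at 3.3, with a likely range from 2.7 to 3.9.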

Compound 4, distribution coefficient: 3.1
The estimate for compound 4 lay 0.20 log units above the measured number; measured number inside the range.
By their numbers in this assay, from the lowest: compounds 1 and 3 (each within the scatter of the next); then compound 2; then compound 4.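

In this assay, exchanging the 2-(hydroxymethyl)phenyl group, para to a large group, for 3-chloro-2-methoxyphenyl gives a single-place step of a number 1.00 log units higher from compound 1 to compound 4 (beyond the scatter), which shows that the read-out responds to the group at this position. This exchange alters several features at once: the group that leaves carries a hydrogen-bond donor, while the group that enters carries none, adds a chlorine and has one more heavy atom, so the step belongs to the exchange as a whole and cannot be divided among these features. Nothing available accounts for the size or direction of this step, so its cause remains unknown.

The compounds shown leave open how much of the step would remain with a simpler group at this position, such as plain phenyl, 3-chlorophenyl or 2-methoxyphenyl, each of which would separate the chlorine from the methoxy group. They also leave open whether the same exchange would give a similar step with a methyl ester in place of the primary amide on the side chain.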